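This account rests on a few compounds, and the source may have more. Where it says the series, first, only, none or still open, it means among the compounds named here.

Working notes on the series. In an assay on cells for agonist activity at vitamin D3 receptor (Homo sapiens), with a stated time of 96 h (on this read-out lower numbers stand for an effect already at smaller amounts and higher numbers for an effect only at larger amounts of compound), compound 1 `CCn1c(C(=O)N(CCC#N)CCC#N)ccc1C(CC)(CC)c1ccc(OCCC(O)(CC)CC)c(C)c1` reaches only the assay limit, > 10000 nM. Compound 3 `CCC(C)C(NC(=O)c1ccc(C(CC)(CC)c2ccc(OCCC(O)(CC)CC)c(C)c2)n1CC)C(=O)OC` likewise stops at the limit of > 10000 nM in this assay. Among the measured compounds shown here, compound 2 `CCn1c(C(=O)Nc2cccc(C(F)(F)F)c2)ccc1C(CC)(CC)c1ccc(OCCC(O)(CC)CC)c(C)c1` is the one member with a measured number, 5900 nM in this assay; the other two values shown are the limit of > 10000 nM in this assay, at which 2 of the 3 values shown sit. The step from compound 2 to compound 4 `CCC(C)C(CO)NC(=O)c1ccc(C(CC)(CC)c2ccc(OCCC(O)(CC)CC)c(C)c2)n1CC` alters the group on the amide-type nitrogen: 1-(hydroxymethyl)-2-methylbutyl in place of 3-(trifluoromethyl)phenyl on an amide-type nitrogen. The measured step that bears on it is an at least 1.6-fold higher number from compound 2 to compound 3 (0.22 log units; that floor lies within the scatter), a change on the same amide-type nitrogen, likewise away from 3-(trifluoromethyl)phenyl toward a branched chain. The step of a 2.0-fold higher number from compound 2 to compound 4 (0.31 log units; beyond the scatter) is therefore expected, toward the limit. Compound 4 is estimated at 12000 nM, with a range of 4000 nM to 40000 nM.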

Compound 4, half-maximal effective concentration: 450 nM
Estimate against measurement, compound 4: 27-fold (1.43 log units) above; the whole stated range lies above it.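

In this assay, the group on the amide-type nitrogen can lift the series well past compound 2, with 1-(hydroxymethyl)-2-methylbutyl giving a 13-fold lower number from compound 2 to compound 4 (1.12 log units; beyond the scatter). A branched chain alone is not enough: hydroxymethyl in place of methoxycarbonyl on the saturated chain carbon gives an at least 22-fold lower number from compound 3 to compound 4 (1.34 log units; beyond the scatter). The change from the group of compound 1 gives an at least 22-fold lower number from compound 1 to compound 4 (1.34 log units; beyond the scatter), and these last two steps are floors set by assay limits: the limit of > 10000 nM in this assay, at which 2 of the 4 values shown sit.

Still open, as far as these compounds go, is whether the hydroxymethyl can be replaced by an aminomethyl, a carboxylic acid or a methyl ether. Also open, from the compounds shown here alone, is how a shorter or longer chain on that carbon would read.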